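This account rests on a few compounds, and the source may have more. Where it says the series, first, only, none or still open, it means among the compounds named here.

Compound 2 `Cn1cncc1CN1CC(N(CC2CCN(C(=O)c3cccs3)CC2)S(=O)(=O)c2ccccn2)Cc2cc(C#N)ccc21` and compound 1 `CCNC(=O)N1CCC(CN(C2Cc3cc(C#N)ccc3N(Cc3cncn3C)C2)S(=O)(=O)c2ccccn2)CC1` share one core and differ only in the group on the carbonyl carbon of the piperidine amide. In an ADME assay on Caco-2 cells (Homo sapiens) for permeability, in the apical to basolateral direction (on this read-out higher numbers stand for higher permeability and lower numbers for lower permeability), compound 1 gives 0.6 10^-6 cm/s, and in this assay compound 2 gives 0.5 10^-6 cm/s. Compound 2 holds the lower of the two numbers, but the change from compound 1 to compound 2 was a 1.2-fold lower number from compound 1 to compound 2 (0.08 log units; within the scatter), so the two are not told apart on this read-out.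

Among the compounds with values here, compound 3 `Cn1cncc1CN1CC(N(CC2CCN(C(=O)CC(F)(F)F)CC2)S(=O)(=O)c2ccccn2)Cc2cc(C#N)ccc21` follows from compound 2 by one change at the same position: 2,2,2-trifluoroethyl in place of thiophen-2-yl on a carbonyl carbon The one measured step that bears on it is the earlier exchange on the same carbonyl carbon, and that step, a 1.2-fold lower number from compound 1 to compound 2 (0.08 log units; within the scatter), did not move the number beyond the scatter. On that basis the step from compound 2 to compound 3 is expected to be no change at the digits printed from compound 2 to compound 3 (within the scatter), that is, no shift that can be separated from the noise. Compound 3 is therefore estimated to give 0.5 10^-6 cm/s in this assay, with a range from 0.25 10^-6 cm/s to 1 10^-6 cm/s.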

Compound 3, apparent permeability: 0.5 10^-6 cm/s
For compound 3 middle estimate and measured number coincide at the digits printed; the measured number falls inside the stated range.
By their numbers in this assay, from the lowest: compounds 2, 3 and 1 (each within the scatter of the next).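

In this assay, the exchange of a ring for an open chain on this carbonyl carbon reads as no change at the digits printed from compound 2 to compound 3 (within the scatter). Thiophen-2-yl and 2,2,2-trifluoroethyl have the same count of 5 heavy atoms but differ in ring content and in hydrogen-bond acceptors, 1 against 0, and no shift separable from the noise goes with that difference in these two compounds. Read against ethylamino, the new group gives a 1.2-fold lower number from compound 1 to compound 3 (0.08 log units; within the scatter), so all three groups at this position, ethylamino, thiophen-2-yl and 2,2,2-trifluoroethyl, remain indistinguishable on this read-out. Nothing available offers an explanation for this flat reading.

The compounds shown leave open whether a primary amine, a carboxylic acid or a longer alkyl chain on the same carbonyl carbon would give a number that stands clear of these three. They also leave open whether an exchange elsewhere on the shared core, such as at the nitrile, would move the number beyond the scatter of this assay.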